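The source may hold more compounds than are shown below. What is called first, only, known or untested is meant among the compounds shown, and "the series" means these compounds.

Working notes on the series. Compound 1 `O=C(NO)[C@H]1CC2(CC2)CN[C@@H]1C(=O)N1CCC(c2ccccc2)CC1` serves as the reference point. In an assay on BT-474 cells for inhibition of disintegrin and metalloproteinase domain-containing protein 10 (Homo sapiens) (on this read-out higher numbers stand for weaker inhibition and lower numbers for stronger inhibition), compound 1 gives 137 nM, the second highest of the three numbers in hand. Compound 3 `CS(=O)(=O)N1CC2(CC2)C[C@H](C(=O)NO)[C@H]1C(=O)N1C=CC(c2ccccc2)CC1`, which carries a methanesulfonyl group in place of the hydrogen on the amine nitrogen in a ring and differs elsewhere as well, gives 93 nM in this assay, a number within the scatter of compound 1. Compound 2 `Cc1cc(N2CCN(C(=O)[C@H]3NCC4(CC4)C[C@@H]3C(=O)NO)CC2)ccc1C#N`, with a different amide partner, gives 594 nM in this assay, the highest of the three numbers and beyond the scatter from compound 1. Compound 4 `COC(=O)N1CC2(CC2)C[C@H](C(=O)NO)[C@H]1C(=O)N1CCC(c2ccccc2)CC1` is not yet measured; it differs from compound 1 by methoxycarbonyl in place of hydrogen on an amine nitrogen in a ring. Going by the values given here, no pair of measured compounds differs in exactly this way, so the expected step rests on compound 3, whose capped amine nitrogen comes with a number within the scatter of compound 1. The expected step, a 1.2-fold lower number from compound 1 to compound 4 (0.10 log units; within the scatter), is small, in the direction of a slightly lower number and not beyond the scatter. Compound 4 is expected to give 110 nM in this assay, with a range of 40 nM to 300 nM, because compound 3 gives 93 nM with a methanesulfonyl group on the amine nitrogen in a ring.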

Compound 4, half-maximal inhibitory concentration: 169 nM
Estimate against measurement, compound 4: 1.5-fold (0.19 log units) below; the measured number falls inside the stated range.
By their numbers in this assay, from the lowest: compounds 3, 1 and 4 (each within the scatter of the next); then compound 2.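

In this assay the capping of the amine nitrogen in a ring can now be read on its own: methoxycarbonyl in place of hydrogen gives a 1.2-fold higher number from compound 1 to compound 4 (0.09 log units; within the scatter) on the otherwise unchanged core. Compound 3 could not show this, since its methanesulfonyl group comes with a second difference in the amide partner. At this position, then, the free amine hydrogen can be exchanged for methoxycarbonyl with no change in the number beyond the scatter, and no measurement available here speaks to why.

The compounds shown leave open whether other groups on this nitrogen, such as acetyl, a longer alkoxycarbonyl chain or benzyl, behave the same way. As far as these compounds go, whether methoxycarbonyl has the same outcome with the amide partner of compound 2 also remains open.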